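A few compounds are considered here, and "the series" means these few. Any claim that something is new, unique, unknown or untested is made for them only; others in the source may bear on it.

Compound 1 `c1ccc(C(/N=C2\CCCCN2)C2CC2)cc1`, 1%; compound 2 `Cc1ccc(C(/N=C2\CCCCCCCN2)C2CC2)c(C)c1`, 17%; compound 3 `c1ccc(C(/N=C2\CCCCCN2)C2CCC2)cc1`, 14%.

All three were measured in a functional assay on the whole organism (plasma, strain Sprague-Dawley) with Rattus norvegicus as the target, with a stated time of 2 h, at a dose of 12.5 mg/kg by the oral route; on this read-out higher numbers stand for a stronger effect at the one dose given and lower numbers for a weaker effect. Compound 1 gives the lowest number of the three, with 1%; compound 3 lies higher by a gap beyond the usual scatter, and compound 2 lies higher still, also beyond the scatter. Compound 4 `c1ccc(C(/N=C2\CCCCN2)c2ccco2)cc1` has not yet been measured. It differs from compound 1 in one place: furan-2-yl in place of cyclopropyl on a saturated chain carbon bound to an aromatic carbon and a double-bonded nitrogen. Among the compounds with values here, no measured pair shows what such a change does, so any expectation rests only on the weak read-out of compound 1. The step is expected to be small, a modest rise at best, and it may well stay within the scatter: a number 7 percentage points higher from compound 1 to compound 4 (within the scatter). Compound 4 is therefore estimated at 8%, within a range from 0% to 30%.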

Compound 4, a percentage reported as inhibition, in the whole organism at one dose (the size of the read-out at that dose, not a potency): 13%
For compound 4 the middle estimate is 5 percentage points below the measured one; the measured number falls inside the stated range.
By their numbers in this assay, from the lowest: compound 1; then compounds 4, 3 and 2 (each within the scatter of the next).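

Putting furan-2-yl in place of cyclopropyl on a saturated chain carbon bound to an aromatic carbon and a double-bonded nitrogen gives a number 12 percentage points higher from compound 1 to compound 4 (beyond the scatter) in this assay. This single-place comparison shows that the group at this position can change the read-out, and that a five-membered aromatic ring with one hetero atom is tolerated there. Nothing available explains the rise.

Phenyl or thiophen-2-yl at this place would help show whether the furan oxygen matters. As far as these compounds go, whether the same change acts alike on the core of compound 3 remains open.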